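The compounds below may be only part of what the source reports. "The series", "measured", "known", "first", "only" and "open" are said of these compounds alone.

Measured so far:
compound 1, `CCCn1c(=O)c2nc(-c3ccc(OCC(=O)NCCN=C(S)Nc4ccc(F)cc4)cc3)[nH]c2n(CCC)c1=O` — 15.5 nM
compound 2, `CCCn1c(=O)c2nc(-c3ccc(OCC(=O)NCCN=C(S)Nc4ccc(Br)cc4)cc3)[nH]c2n(CCC)c1=O` — 7.26 nM

In an assay on brain for binding affinity to adenosine receptor A1 (Rattus norvegicus), read by radioligand binding (a lower number here means a stronger inhibitor, a higher number a weaker inhibitor), compound 2 gives 7.26 nM, the lower of the two numbers; compound 1 sits above it by a 2.1-fold lower number from compound 1 to compound 2 (0.33 log units; beyond the scatter). Compound 3, `CCCn1c(=O)c2nc(-c3ccc(OCC(=O)NCCN=C(S)Nc4ccc(S(=O)(=O)O)cc4)cc3)[nH]c2n(CCC)c1=O`, has not yet been measured in this assay. It differs from compound 2 in one place: sulfo in place of bromo on an aromatic carbon. Going by the values given here, the only measured step, a 2.1-fold lower number from compound 1 to compound 2 (0.33 log units; beyond the scatter), exchanges one halogen for another and gives no direct guide to replacing a halogen with a sulfo group; no measured pair shows that change. In this assay a loss of affinity is expected for compound 3, of uncertain size, because the known step of a 2.1-fold lower number from compound 1 to compound 2 (0.33 log units; beyond the scatter) covers a different exchange. The expected step is a 5.5-fold higher number from compound 2 to compound 3 (0.74 log units; beyond the scatter). For compound 3 the estimate is 40 nM, with a plausible range from 8 nM to 250 nM.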

Compound 3, inhibition constant: 367 nM
The estimate for compound 3 lay 9.2-fold (0.96 log units) below the measured number; measured number outside the range, above it.
By their numbers in this assay, from the lowest: compound 2; then compound 1; then compound 3.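

Swapping one halogen for another at this position on the aromatic ring changed the number only modestly, but in this assay the position proves far from indifferent to the group it carries: sulfo in place of bromo gives a 51-fold higher number from compound 2 to compound 3 (1.70 log units; beyond the scatter), and sulfo in place of fluoro gives a 24-fold higher number from compound 1 to compound 3 (1.37 log units; beyond the scatter). Both of these large steps go the same way, so either halogen gives a much lower number than the sulfo group, with the rest of the molecule unchanged. No measurement given here bears on why the sulfo group raises the number so much.

Still open, as far as these compounds go, is whether this loss is particular to the sulfo group or would also appear with a carboxylic acid or an amine at this position. Also open, from the compounds shown here alone, is whether a plain hydrogen there would give a number closer to the halogens or to compound 3.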